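The source may hold more compounds than are shown below. What is called first, only, known or untested is meant among the compounds shown, and "the series" means these compounds.

Working notes on the series. Compound 1 `NS(=O)(=O)c1ccc(Nc2nccc(-c3cccnc3)n2)cc1` gives the lowest of the three numbers in a functional assay for inhibition, with Homo sapiens as the target (a higher number here means a weaker inhibitor, a lower number a stronger inhibitor), with compound 1 at 200 nM. Going by the values given here, compound 2 `CC1CCN(c2cccc(Nc3nccc(-c4cccnc4)n3)c2)CC1` gives 1200 nM and compound 3 `NS(=O)(=O)c1ccc(Nc2nccc(-c3ccncc3)n2)cc1` gives 5100 nM, so compound 1 stands apart from both on this assay; the single step within the set, a 26-fold higher number from compound 1 to compound 3 (1.41 log units; beyond the scatter), concerns the pyridyl and not the group at issue here. Compound 4 `CN(C)c1ccc(Nc2nccc(-c3cccnc3)n2)cc1` differs from compound 1 by dimethylamino in place of sulfamoyl on an aromatic carbon. Among the compounds with values here, no measured step touches this position, so the only guide is that compound 2, carrying an amine on the shared core, sits higher than compound 1. A loss is therefore expected, estimated as a 7.5-fold higher number from compound 1 to compound 4 (0.88 log units; beyond the scatter), giving compound 4 an expected 1500 nM within 400 nM to 6000 nM.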

Compound 4, half-maximal inhibitory concentration: 2800 nM
For compound 4 the middle estimate is 1.9-fold (0.27 log units) below the measured one; measured number inside the range.
By their numbers in this assay, from the lowest: compound 1; then compound 2; then compounds 4 and 3 (each within the scatter of the next).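

Going by these compounds alone, this position responds strongly to the exchange: on the shared core, dimethylamino in place of sulfamoyl in this assay gives a 14-fold higher number from compound 1 to compound 4 (1.15 log units; beyond the scatter) as the first measured step here. The earlier compounds offered no one-place comparison at this position, so sulfamoyl is now directly shown to outperform dimethylamino. No supporting data explain the size of this step.

As far as these compounds go, whether the step follows the loss of sulfamoyl or the entry of dimethylamino remains open. Also open, from the compounds shown here alone, is how a primary amine or methylsulfonyl would read at this position.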